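The source may report more compounds than this note shows. Statements on the series, on what has been measured and on what is new or still open speak of the compounds shown alone.

Measured compounds:
- compound 1, `CCN(Cc1ccccc1C(F)(F)F)C(=O)C1CCN(S(=O)(=O)c2ccc3[nH]ncc3c2)CC1`: 96%
- compound 2, `O=C(C1CCN(S(=O)(=O)c2ccc3[nH]ncc3c2)CC1)N(Cc1ccccc1C(F)(F)F)C1CCC1`: 84%

In a functional assay on CHO cells for positive allosteric modulation of muscarinic acetylcholine receptor M5 (Homo sapiens), read by calcium flux (a higher number here means a larger maximal response, a lower number a smaller maximal response), compound 1 gives 96%, and compound 2 gives 84%. Of the two numbers seen so far, compound 2 stands lowest, with compound 1 above it beyond the usual scatter. Within the data shown here, the one measured step, a number 12 percentage points lower from compound 1 to compound 2 (beyond the scatter), shows that enlarging the group on the amide-type nitrogen from ethyl to a cyclobutyl ring lowers the maximal response by a modest amount.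

Compound 3, `CCC(C)N(Cc1ccccc1C(F)(F)F)C(=O)C1CCN(S(=O)(=O)c2ccc3[nH]ncc3c2)CC1`, carries the change (sec-butyl in place of cyclobutyl on an amide-type nitrogen). The new group keeps the size of the cyclobutyl but has no ring. Among the measured compounds shown here, no measured step swaps a ring for a chain of equal size, so the only guide is the modest loss seen when ethyl became cyclobutyl; a branched chain between those two cases suggests little movement, perhaps a small recovery toward compound 1.

Compound 3 is therefore expected to give about 88%, with a likely range from 76% to 99%. The expected step is a number 4 percentage points higher from compound 2 to compound 3 (within the scatter), at or near the scatter.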

Compound 3, largest response reached (reported as percent of maximum), in percent of the reference or control that the assay uses: 100%
Compound 3: the middle estimate sits 12 percentage points below what was measured, and the stated range ends below it.
By their numbers in this assay, from the lowest: compound 2; then compounds 1 and 3 (each within the scatter of the next).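

In this assay, the swap of cyclobutyl for sec-butyl gives a number 16 percentage points higher from compound 2 to compound 3 (beyond the scatter) even though both groups hold 4 carbons on the amide-type nitrogen, so the number of atoms alone does not set the response at this position. Placing an ethyl in place of hydrogen on the saturated chain carbon bound to that nitrogen gives a number 4 percentage points higher from compound 1 to compound 3 (within the scatter) and so a larger open chain here keeps the response of the smaller ethyl group, while among these three compounds only the cyclobutyl ring stands apart. Nothing measured here explains why the ring and the open chain differ. Still open, as far as these compounds go, is whether a longer chain such as n-hexyl would behave like sec-butyl. Also open, from the compounds shown here alone, is how a larger ring such as cyclohexyl, or a group carrying an amine, would fare at this position.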